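The compounds below may be only part of what the source reports. "The series", "measured", "known", "first", "only" and "open" are said of these compounds alone.

Measured compounds:
compound 1, `Nc1nc(=O)ccn1[C@@H]1O[C@H](COP(=O)(O)O)[C@@H](O)[C@H]1O`, 4980 nM
compound 2, `CSc1nc(=O)ccn1[C@@H]1O[C@H](COP(=O)(O)O)[C@@H](O)[C@H]1O`, > 100000 nM

In an in vitro functional assay on 1321-N1 cells for agonist activity at P2Y purinoceptor 4 (Homo sapiens), read by scintillation proximity assay and inositol phosphate accumulation (a higher number here means that more compound is needed for the effect, a lower number that less compound is needed), compound 1 gives 4980 nM. For compound 2 the reading is only a limit, > 100000 nM, as marked by the limit of > 100000 nM in this assay, at which 1 of the 2 values shown sits. Compound 2 thus stands at the weak end of the two values shown, reached through an at least 20-fold higher number from compound 1 to compound 2 (1.30 log units; beyond the scatter), a loss that is large and beyond the scatter. Compound 3, `O=c1ccn([C@@H]2O[C@H](COP(=O)(O)O)[C@@H](O)[C@H]2O)c(SCc2ccccc2)n1`, differs from compound 2 by phenyl in place of hydrogen on a saturated chain carbon bound to a sulfur. Among the compounds with values here, no measured step covers a change of this kind: the single measured step, an at least 20-fold higher number from compound 1 to compound 2 (1.30 log units; beyond the scatter), exchanges the group on the aromatic carbon and says nothing about lengthening the chain on the sulfur. With compound 2 already at the limit, compound 3 is expected to remain near that limit in this assay, at about 100000 nM, between 20000 nM and 300000 nM. The step is estimated as a number no higher from compound 2 to compound 3 (the limit leaves the size open), within the scatter.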

Compound 3, half-maximal effective concentration: > 100000 nM
Compound 3 gave a limit, no number; the forecaster's own chance of this, stated with the estimate: 60%; the middle value sits exactly at the limit.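

In this assay, replacing the amino group with benzylsulfanyl gives an at least 20-fold higher number from compound 1 to compound 3 (1.30 log units; beyond the scatter), so a second sulfur-linked group, this one carrying a phenyl, shows the same large loss as methylsulfanyl. Compound 3 reads only as a limit, > 100000 nM. The step from compound 2 to compound 3 cannot be read, so adding phenyl on the saturated chain carbon bound to a sulfur brings no readable recovery, and both compounds stay at the same ceiling: the limit of > 100000 nM in this assay, at which 2 of the 3 values shown sit.

Going by these compounds, it remains open how far compound 2 and compound 3 lie past that limit, and whether any group other than amino can keep the effect on this aromatic carbon. A methylamino or a methoxy group on that carbon would test this.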